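A few compounds are considered here, and "the series" means these few. Any claim that something is new, unique, unknown or untested is made for them only; others in the source may bear on it.

Compound 1 `O=C(C1CC2(CCN(C3CCOCC3)CC2)C1)N1CCCN(C2CCC2)CC1`: -0.89
Compound 2 `CC(C)N1CCCN(C(=O)C2CC3(CCN(C4CCOCC4)CC3)C2)CC1`: -1.78
Compound 3 `CC(C)N1CCN(C(=O)C2CC3(CCN(C4CCOCC4)CC3)C2)CC1`: -0.74

In a physicochemical assay for lipophilicity, read by HPLC, using the shake flask method, measured as octanol-water partition (on this read-out higher numbers stand for higher lipophilicity and lower numbers for lower lipophilicity), compound 2 gives -1.78, the lowest of the three numbers and clearly separated from the other two. The next compound, compound 4 `CC(C)N1CCCN(C(=O)C2CC3(CCN(C(=O)c4ccccc4)CC3)C2)CC1`, keeps the rest of compound 2 and carries one change: benzoyl in place of oxan-4-yl on an amine nitrogen in a ring.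

Going by the values given here, no measured step covers this exchange. Among the compounds with values here, the only one available is a number 0.89 log units lower from compound 1 to compound 2 (beyond the scatter), and it concerns isopropyl in place of cyclobutyl at a different amine nitrogen. It bears on the new change only indirectly, showing that a single exchange of a group in this series can move the number beyond the scatter. A rise larger than that step is expected, since compound 2 already sits at the bottom of the set and the entering benzoyl is an aromatic group, but this remains a judgment. The expected change is a number 1.58 log units higher from compound 2 to compound 4 (beyond the scatter). For compound 4 the estimated value is -0.2, with an expected range from -1 to 0.7.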

Compound 4, distribution coefficient: 1.63
Compound 4: the middle estimate sits 1.83 log units below what was measured, and the stated range ends below it.
By their numbers in this assay, from the lowest: compound 2; then compounds 1 and 3 (each within the scatter of the next); then compound 4.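

In this assay the change from oxan-4-yl to benzoyl on this amine nitrogen in a ring appears as a number 3.41 log units higher from compound 2 to compound 4 (beyond the scatter) and counts as large. The earlier compounds shown here offered only a number 0.89 log units lower from compound 1 to compound 2 (beyond the scatter) at a different amine nitrogen, a modest step, so this position shows a much wider reach than the set had revealed. The exchange leaves the counts of hydrogen-bond donors and acceptors unchanged and brings no net charge, so those counts do not separate the two groups, while a six-membered aromatic ring of carbon only and a double bond outside aromatic rings enter.

The compounds shown do not settle whether the aromatic ring or the carbonyl carries the step, a question that a benzyl or an acetyl group on this nitrogen would bear on. No measurement at hand explains the size of the step.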